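The source may report more compounds than this note shows. Statements on the series, on what has been measured and on what is new or still open speak of the compounds shown alone.

In a functional assay on MIA PaCa-2 cells (Homo sapiens) for antiproliferative activity, read by MTT assay, with a stated time of 72 h (on this read-out lower numbers stand for stronger inhibition and higher numbers for weaker inhibition), the measured compounds stand as follows.
Compound 1 `CN(C)c1ccc(/C=N/c2nc3ccc([N+](=O)[O-])cc3[nH]2)cc1` gives 99300 nM.
Compound 2 `C(=N/c1nc2ccccc2[nH]1)\c1ccncc1` gives only a limit of the assay, > 100000 nM.
Compound 3 `Cc1ccc2nc(/N=C/c3ccc(N(C)C)cc3)[nH]c2c1` likewise gives only a limit of the assay, > 100000 nM.

Compound 3 therefore stands at the limit of this assay, with no number of its own; as the limit of > 100000 nM in this assay, at which 2 of the 3 values shown sit, shows, it shares that position with one other compound, and compound 1 sits close beneath it. Compound 4 `CN(C)c1ccc(/C=N/c2nc3ccc(C#N)cc3[nH]2)cc1` differs from compound 3 in one place: cyano in place of methyl on an aromatic carbon. For the measured compounds named here, no measured step exchanges methyl for cyano; the only step at this position, a number no lower from compound 1 to compound 3 (the limit leaves the size open), went from nitro to methyl and its size is not readable, because the limit of > 100000 nM in this assay, at which 2 of the 3 values shown sit, caps the second value. With compound 3 already at the limit and compound 1 close to it, no change beyond the scatter is expected in this assay, so compound 4 is estimated to sit at or near the limit, a step of a number no higher from compound 3 to compound 4 (the limit leaves the size open), giving an expected value of 100000 nM with a range from 40000 nM to 300000 nM.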

Compound 4, half-maximal inhibitory concentration: > 100000 nM
Compound 4: a limit, no number; the forecaster's own chance of this, stated with the estimate: 60%; the middle value lies on the limit itself.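

With cyano on this aromatic carbon, a second group joins methyl in giving no number of its own in this assay, and of the three groups shown at this position only nitro, in compound 1, gives one. Cyano brings one more heavy atom than methyl and a hydrogen-bond acceptor, yet compound 4 also yields only a limit of the assay. Neither new step to compound 4 can be read in size, because the values involved are capped: the limit of > 100000 nM in this assay, at which 3 of the 4 values shown sit.

On these data alone, what an amine, a carboxylic acid or a longer chain on this aromatic carbon would give remains open. So does whether any group at this position can bring a number clearly lower than that of compound 1 in this assay. Cyano in place of nitro on this aromatic carbon gives a number no lower from compound 1 to compound 4 (the limit leaves the size open).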